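Compound 1 to compound 4: bromo in place of methyl

The compounds below may be only part of what the source reports. "The series", "measured", "known", "first", "only" and "open" are said of these compounds alone.

In a functional assay on DU-145 cells (Homo sapiens) for inhibition, read by trypan blue exclusion, with a stated time of 96 h (a higher number here means a weaker inhibitor of growth, a lower number a stronger inhibitor of growth), compound 1 `Cc1ccc(S/C(=C/c2c[nH]c3ccccc23)C(=O)c2ccc(Br)cc2)cc1` gives 10000 nM and compound 3 `Cc1ccc(S/C(=C/c2ccc(Cl)cc2)C(=O)c2ccc(Br)cc2)cc1` gives the same 10000 nM at the digits shown, while compound 2 `Cc1ccc(S/C(=C/c2ccc(Cl)c(Cl)c2)C(=O)c2ccc(Br)cc2)cc1` gives 50000 nM as the highest number of the three. Going by the values given here, compound 4 `O=C(/C(=C\c1c[nH]c2ccccc12)Sc1ccc(Br)cc1)c1ccc(Br)cc1` has no measurement yet. It differs from compound 1 by bromo in place of methyl on an aromatic carbon, para to a large group (bromo in place of methyl on an aromatic carbon), which reads as (4-bromophenyl)sulfanyl in place of (4-methylphenyl)sulfanyl. Among the compounds with values here, no measured step touches this place, so the evidence is indirect. Replacing 1H-indol-3-yl gave no change at the digits printed from compound 1 to compound 3 (within the scatter) with 4-chlorophenyl and a 5.0-fold higher number from compound 1 to compound 2 (0.70 log units; beyond the scatter) with 3,4-dichlorophenyl. Hydrogen in place of chloro on an aromatic carbon gave a 5.0-fold lower number from compound 2 to compound 3 (0.70 log units; beyond the scatter) as the only step of a single substituent on an aromatic carbon, and it occurs elsewhere in the molecule. It leaves a modest move in either direction open, but no step beyond the scatter is expected in this assay here. An estimated step of no change at the digits printed from compound 1 to compound 4 (within the scatter) is the working expectation. Compound 4 is estimated at 10000 nM with 4000 nM to 30000 nM as the expected range.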

Compound 4, concentration for 50% growth inhibition: 1000 nM
For compound 4 the middle estimate is 10-fold (1.00 log units) above the measured one; the whole stated range lies above it.
By their numbers in this assay, from the lowest: compound 4; then compounds 1 and 3 (each within the scatter of the next); then compound 2.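

This position on the (4-methylphenyl)sulfanyl group is the first in the series shown to be probed directly, and it proves responsive: in this assay, bromo in place of methyl gives a 10-fold lower number from compound 1 to compound 4 (1.00 log units; beyond the scatter). One heavy atom replaces one heavy atom here, with no change in hydrogen-bond donors, acceptors or net charge, yet the number moves beyond the scatter, unlike the exchange of 1H-indol-3-yl for 4-chlorophenyl, which gave no change at the digits printed from compound 1 to compound 3 (within the scatter). No measurement at hand accounts for this step.

On these data alone, with a single pair at this place, it remains open whether the lower number follows from bromo itself or from the loss of methyl, and how a methoxy group or a carboxylic acid here would read. Also open, as far as these compounds go, is whether the same step would hold on the 4-chlorophenyl analogue, compound 3.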